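A few compounds are considered here, and "the series" means these few. Any claim that something is new, unique, unknown or untested is made for them only; others in the source may bear on it.

Series notes. The shared core of compound 1 `Nc1sc(-c2ccc(Cl)cc2)c(-c2ccc(Cl)cc2)c1C(=O)N1CCCCC1` carries an amide on the carbonyl carbon; in a functional assay on PC-3 cells (Homo sapiens) for inhibition, read by sulforhodamine B assay, with a stated time of 72 h (a lower number here means a stronger inhibitor, a higher number a weaker inhibitor), compound 1 gives 14300 nM, the highest of the two numbers in hand. Compound 2 `Nc1sc(-c2ccc(Cl)cc2)c(-c2ccc(Cl)cc2)c1C(=O)Nc1ccccc1` returns only a limit in this assay, > 50000 nM. That limit is the one noted as the limit of > 50000 nM in this assay, at which 1 of the 3 values shown sits. Compound 3 `Nc1sc(-c2ccc(Cl)cc2)c(-c2ccc(Cl)cc2)c1C(=O)NC1CCC(O)CC1` gives 5670 nM in this assay. Two measured steps start from compound 1 and change the same carbonyl carbon: an at least 3.4-fold higher number from compound 1 to compound 2 (0.54 log units; beyond the scatter) and a 2.5-fold lower number from compound 1 to compound 3 (0.40 log units; beyond the scatter). The remaining pair reads an at least 8.8-fold lower number from compound 2 to compound 3 (0.94 log units; beyond the scatter). Compound 4 `CC(C)(C)NC(=O)c1c(N)sc(-c2ccc(Cl)cc2)c1-c1ccc(Cl)cc1` differs from compound 1 thus: (tert-butyl)amino in place of piperidin-1-yl on a carbonyl carbon. Both steps from compound 1 bear on this change: the anilino step pushed the number up to a limit, the (4-hydroxycyclohexyl)amino step brought it modestly down. Compound 4 carries an aliphatic secondary amide, as compound 3 does, but without the hydroxy of that group, so a modest step toward a lower number, or none beyond the scatter, is expected. The estimate for compound 4 in this assay is 10000 nM, expected to fall between 4000 nM and 30000 nM. This expectation means a step of a 1.4-fold lower number from compound 1 to compound 4 (0.16 log units; within the scatter).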

Compound 4, half-maximal inhibitory concentration: 15100 nM
Estimate against measurement, compound 4: 1.5-fold (0.18 log units) below; low and high end bracket the measured number.
By their numbers in this assay, from the lowest: compound 3; then compounds 1 and 4 (each within the scatter of the next). At a limit, above all of these: compound 2.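

In this assay, losing the piperidin-1-yl ring and gaining the amide hydrogen on this carbonyl carbon leaves the number in place: a 1.1-fold higher number from compound 1 to compound 4 (0.02 log units; within the scatter). An aliphatic secondary amide is therefore not enough to reach the level of compound 3, as the 4-hydroxycyclohexyl group separates from tert-butyl with a 2.7-fold higher number from compound 3 to compound 4 (0.43 log units; beyond the scatter). Tert-butyl also stands apart from phenyl on the amide-type nitrogen with an at least 3.3-fold lower number from compound 2 to compound 4 (0.51 log units; beyond the scatter), a step that rests on a limit of the assay for compound 2: the limit of > 50000 nM in this assay, at which 1 of the 4 values shown sits.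

From the compounds shown here alone, the step from compound 3 changes the hydroxy and the ring together, so the part each plays remains open. Also open, going by these compounds, is whether plain cyclohexyl, 2-hydroxyethyl or 4-aminocyclohexyl on the amide-type nitrogen would give a number like that of compound 3.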